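The compounds below may be only part of what the source reports. "The series", "measured", "known", "first", "only" and "open" are said of these compounds alone.

In an ADME assay on microsomes from liver (Homo sapiens) for metabolic stability (on this read-out higher numbers stand for a longer-lived compound and lower numbers for a shorter-lived compound), compound 3 (`COc1cc(OCc2csc(-c3ccc(C(C)(C)O)cc3)n2)c2cc(-c3cn4nc(OC)sc4n3)oc2c1`) gives 1.83 h and sits within the scatter of the two other measured compounds. Compound 1 (`COc1cc(OCc2cccc(-c3ccc(C#N)cn3)c2)c2cc(-c3cn4nc(OC)sc4n3)oc2c1`) gives 1.57 h and compound 2 (`COc1cc(OCc2cccc(-c3cnc(OC)cn3)c2)c2cc(-c3cn4nc(OC)sc4n3)oc2c1`) gives 1.48 h on the same read-out, so the three values do not separate.

The next change leads to compound 4 (`COc1cc(OCc2csc(-c3ccc(C(=O)O)cc3)n2)c2cc(-c3cn4nc(OC)sc4n3)oc2c1`): carboxy in place of 1-hydroxy-1-methylethyl on an aromatic carbon. In words, this is carboxy in place of 1-hydroxy-1-methylethyl on an aromatic carbon, para to a large group, turning 4-(1-hydroxy-1-methylethyl)phenyl into 4-carboxyphenyl.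

For the measured compounds named here, only one single-place step is available as a guide: a 1.1-fold lower number from compound 1 to compound 2 (0.03 log units; within the scatter). It lies within the scatter, but it involves other groups, so it bears on this change only indirectly. Going by the values given here, no measured compound carries carboxy, and no measured step starts from compound 3, so the evidence for this change is thin.

With nothing pointing either way, no step beyond the scatter is expected in this assay and no firm direction is assigned. The estimated step is a 1.0-fold lower number from compound 3 to compound 4 (0.01 log units; within the scatter) and remains a small expected change. For compound 4 the estimated half-life is 1.8 h with an expected range of 0.9 h to 3.4 h in this series.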

Compound 4, half-life: > 2 h
Compound 4: no number, only a limit; the forecaster's own chance of this, stated with the estimate: 10%; middle value at least 1.1-fold (0.04 log units) from the limit.
By their numbers in this assay, from the lowest: compounds 2, 1 and 3 (each within the scatter of the next). At a limit, above all of these: compound 4.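

In this assay compound 4 gives > 2 h, which is a limit and not a number. For the compounds shown here, this is the first reading of a change at this position, carboxy in place of 1-hydroxy-1-methylethyl on an aromatic carbon, para to a large group, and it gives an at least 1.0-fold higher number from compound 3 to compound 4 (0.03 log units; that floor lies within the scatter), so carboxy at this place shows no loss of half-life, while the size of any gain stays unknown. Going by these compounds alone, compound 4 is also the only compound read at the limit: the limit of > 2 h in this assay, at which 1 of the 4 values shown sits.

Still open, on these data alone, is whether other groups at the same place, such as an amide, a methyl ester or a primary amine, would read like carboxy or like 1-hydroxy-1-methylethyl on this read-out. Also open, as far as these compounds go, is whether the 4-carboxyphenyl result carries over to the aromatic ring systems that compound 1 and compound 2 hold in that part of the molecule, since those compounds differ from compound 4 in more than one place and give no direct comparison.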